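The source may report more compounds than this note shows. Statements on the series, on what has been measured and on what is new or still open speak of the compounds shown alone.

In a functional assay on CNE-2 cells (Homo sapiens) for inhibition, read by MTT assay, with a stated time of 72 h (a higher number here means a weaker inhibitor, a lower number a stronger inhibitor), compound 1 `CNC(=O)CCCCCCCn1nc(-c2cnc3[nH]ccc3c2)c2c(N)ncnc21`, with a methylcarbamoyl group at the end of its chain, gives 8990 nM. Compound 2 `Nc1ncnc2c1c(-c1cnc3[nH]ccc3c1)nn2CCCCCCCCC(=O)NO` gives 2270 nM, which leaves compound 1 with the higher of the two exact numbers. Compound 3 `Nc1ncnc2c1c(-c1cnc3[nH]ccc3c1)nn2CCCC(=O)NO` gives > 150000 nM, which is a limit of the assay and not a number.

Compound 4 `CNC(=O)CCCCCCCn1nc(-c2ccc3oc(N)nc3c2)c2c(N)ncnc21` keeps the chain and alters only the aromatic group on the shared core, where 2-amino-1,3-benzoxazol-5-yl enters: a group of 10 heavy atoms (7 carbon, 2 nitrogen, 1 oxygen; one five-membered aromatic ring with 2 hetero atoms, one six-membered aromatic ring of carbon only) in place of a group of 9 heavy atoms (7 carbon, 2 nitrogen; one five-membered aromatic ring with 1 hetero atom, one six-membered aromatic ring with 1 hetero atom), on an aromatic carbon. For the measured compounds named here, all the measured steps change the chain, not this group. a 4.0-fold lower number from compound 1 to compound 2 (0.60 log units; beyond the scatter) is modest, while an at least 16-fold higher number from compound 1 to compound 3 (1.22 log units; beyond the scatter) and an at least 66-fold higher number from compound 2 to compound 3 (1.82 log units; beyond the scatter) are large. These steps show how far the numbers move with the chain, but none of them tests this exchange, so they bear on it only indirectly. With the chain unchanged, only a small shift is expected in this assay. The expected change is a 1.8-fold lower number from compound 1 to compound 4 (0.25 log units; within the scatter), a slightly lower number that stays within the scatter. For compound 4 the estimated value is 5000 nM, with an expected range of 1000 nM to 20000 nM.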

Compound 4, half-maximal inhibitory concentration: 2250 nM
The estimate for compound 4 lay 2.2-fold (0.35 log units) above the measured number; the range from low to high includes it.
By their numbers in this assay, from the lowest: compounds 4 and 2 (each within the scatter of the next); then compound 1. At a limit, above all of these: compound 3.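

In this assay, putting 2-amino-1,3-benzoxazol-5-yl on this aromatic carbon of a five-membered aromatic ring with 2 nitrogen gives a 4.0-fold lower number from compound 1 to compound 4 (0.60 log units; beyond the scatter). For the compounds shown here, every earlier step changed the chain, so this is the first sign that the number also moves with the aromatic group while the chain stays the same. Nothing in the available evidence bears on why this exchange moves the number.

The exchange alters both rings of the group at once, so the compounds shown cannot assign the step to any one part of it, and a plain phenyl group at this place remains untested here. Going by these compounds, it also remains open whether 2-amino-1,3-benzoxazol-5-yl would give a similar step on the chain of compound 2.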